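From phenyl to pyridin-2-yl on the amide nitrogen

A few compounds are considered here, and "the series" means these few. Any claim that something is new, unique, unknown or untested is made for them only; others in the source may bear on it.

Measured in a functional assay on KB cells (Homo sapiens) for inhibition, read by MTT assay, with a stated time of 24 h, tested at 1 ug/mL; a higher number here means more inhibition of growth at the concentration tested, a lower number less inhibition of growth:
- compound 1 `O=C(CCCCC(S)CCS)NO`: 10.6%
- compound 2 `O=C(CCCCC1CCSS1)Nc1ccccn1`: "not active" (no number reported)
- compound 3 `O=C(CCCCC(S)CCS)Nc1ccccc1`: 11.6%

In this assay compound 3 gives 11.6% and compound 1 gives 10.6%, two numbers within the scatter of each other. Compound 2 carries pyridin-2-yl on a different core and offers no number, only "not active" (no number reported).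

Compound 4 `O=C(CCCCC(S)CCS)Nc1ccccn1` awaits measurement. It has pyridin-2-yl in place of phenyl on an amide-type nitrogen.

Among the measured compounds shown here, the one measured step at that nitrogen is a number 1 percentage points higher from compound 1 to compound 3 (within the scatter), with phenyl in place of hydroxy. On that evidence, no step beyond the scatter is expected in this assay, and no direction can be given.

The expected step is a number 0.6 percentage points lower from compound 3 to compound 4 (within the scatter).

Compound 4 is expected at 11%, with an estimated range from 3% to 22%.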

Compound 4, percent growth inhibition at one concentration: "not active" (no number reported)
No number was reported for compound 4; the estimate stays without a comparison.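

In this assay, among the compounds shown here, compound 4 gives "not active" (no number reported) and no step from compound 3 can be read. The compounds shown leave open how far pyridin-2-yl in place of phenyl shifts growth inhibition on this core, and no measurement at hand explains the result.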